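The source may report more compounds than this note shows. Statements on the series, on what has been measured and on what is new or still open speak of the compounds shown alone.

Compound 2 `CCCn1c(=O)c2nc(-c3cccn3C)[nH]c2n(CCC)c1=O` and compound 1 `CC1(Nc2ncnc3c2ncn3C2O[C@H](CO)[C@@H](O)[C@H]2O)CCCCC1` were both tested in an assay on cell membranes for binding affinity to adenosine receptor A1 (Cavia porcellus), read by radioligand binding; a lower number here means a stronger inhibitor, a higher number a weaker inhibitor. Compound 1 gives 70 nM, and compound 2 gives 140 nM, the higher of the two numbers, though the two lie within the scatter of each other, so no order between them can be claimed. Compound 3 `CCCn1c(=O)c2nc(C(C)(O)CC)[nH]c2n(CCC)c1=O` differs from compound 2 in one place: 1-hydroxy-1-methylpropyl in place of 1-methyl-1H-pyrrol-2-yl on an aromatic carbon. Among the measured compounds shown here, no measured step of this kind is available, so the size of the change is uncertain. Compound 3 is expected to give a higher number, by a step of a 3.6-fold higher number from compound 2 to compound 3 (0.55 log units; beyond the scatter) that goes beyond the scatter, with an estimate of 500 nM in a range from 150 nM to 2000 nM.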

Compound 3, inhibition constant: 240 nM
Compound 3: the middle estimate sits 2.1-fold (0.32 log units) above what was measured, within the range that was stated.
By their numbers in this assay, from the lowest: compounds 1, 2 and 3 (each within the scatter of the next, the first and the last beyond it).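

In this assay, 1-hydroxy-1-methylpropyl in place of 1-methyl-1H-pyrrol-2-yl gives a 1.7-fold higher number from compound 2 to compound 3 (0.23 log units; within the scatter). This aromatic carbon therefore accepts an open group with no ring and a hydrogen-bond donor without a change that can be told from the scatter, so the five-membered aromatic ring is not needed there to stay in this range. No measurement at hand explains this result. Going by these compounds, it remains open whether the hydroxyl contributes at all, as a plain butyl chain would show, and how an amine or a carboxylic acid would read at this carbon.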